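Adding a Chloro Group to Compound 1

The source may report more compounds than this note shows. Statements on the series, on what has been measured and on what is new or still open speak of the compounds shown alone.

Compound 1 `O=C(Nc1ccncc1)Nc1ccccc1C(F)(F)F` gives 100 mg/kg in a functional assay on the whole organism with Mus musculus as the target, in the maximal electroshock model, with a stated time of 30 min; a lower number here means that less compound is needed, a higher number that more compound is needed for the effect. Compound 3 `CN(C)c1ccccc1NC(=O)Nc1ccncc1` gives 100 mg/kg in this assay, and the step of no change at the digits printed from compound 1 to compound 3 (within the scatter). Compound 2 `N#Cc1ccccc1NC(=O)Nc1ccncc1` reaches only the limit of > 300 mg/kg, which is a limit of this assay and not a number (the limit of > 300 mg/kg in this assay, at which 1 of the 3 values shown sits). For the measured compounds named here, the steps of an at least 3.0-fold higher number from compound 1 to compound 2 (0.47 log units; beyond the scatter) and an at least 3.0-fold lower number from compound 2 to compound 3 (0.47 log units; beyond the scatter) show that exchanging the single group on the aromatic carbon can matter. Compound 4 `O=C(Nc1ccncc1)Nc1c(Cl)cccc1C(F)(F)F` differs from compound 1 by chloro in place of hydrogen on an aromatic carbon, a change that keeps the trifluoromethyl group and adds a chloro group. Going by the values given here, no measured step adds a group while keeping the first, so none bears directly on this change. The step of no change at the digits printed from compound 1 to compound 4 (within the scatter) is therefore expected to stay within the scatter. Compound 4 is estimated at 100 mg/kg, between 30 mg/kg and 300 mg/kg.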

Compound 4, minimum effective dose: 100 mg/kg
Compound 4: middle estimate and measured number agree at the digits printed; measured number inside the range.
By their numbers in this assay, from the lowest: compounds 1, 3 and 4 (each within the scatter of the next). At a limit, above all of these: compound 2.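

Where the earlier compounds exchanged one group on the aromatic carbon for another, compound 4 keeps trifluoromethyl and adds chloro ortho to a large group, and this assay gives no change at the digits printed from compound 1 to compound 4 (within the scatter). This position therefore accepts a chloro group in addition to trifluoromethyl without any shift beyond the scatter. Nothing shown accounts for this outcome. As far as these compounds go, whether an amine, a carboxylic acid or a longer chain would be accepted at this position stays open. So does whether chloro would have the same outcome alongside dimethylamino, as in compound 3.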